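A few compounds are considered here, and "the series" means these few. Any claim that something is new, unique, unknown or untested is made for them only; others in the source may bear on it.

Measured so far in a functional assay on UoC-B1 cells (Homo sapiens) for antiproliferative activity, with a stated time of 72 h; on this read-out higher numbers stand for an effect only at larger amounts of compound and lower numbers for an effect already at smaller amounts:
- compound 1 `COc1ccc(-c2cc(=O)c3c(OC)cc(OC)cc3n2S(=O)(=O)c2ccc(OC)cc2)cc1`: "not determined" (no result reported)
- compound 2 `COc1cc(OC)c2c(=O)cc(C(=O)Nc3cccc(N4CCCC4)c3)[nH]c2c1`: > 58600 nM (a limit)

Compound 2 stands only at a limit, > 58600 nM, and no number is available for it. Compound 3 `COc1cc(OC)c2c(=O)cc(C(=O)Nc3cccc(-n4ccnc4)c3)[nH]c2c1` changes one group on an aromatic carbon of a six-membered aromatic ring of carbon only, meta to a large group: 1H-imidazol-1-yl in place of pyrrolidin-1-yl on an aromatic carbon. Among the compounds with values here, no step between measured compounds is available in this assay, so no change beyond the scatter is expected. The expected step is an at least 1.3-fold lower number from compound 2 to compound 3 (0.11 log units; that floor lies within the scatter). For compound 3 the estimated value is 45000 nM, with an expected range of 10000 nM to 100000 nM.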

Compound 3, half-maximal effective concentration: > 16300 nM
Compound 3: no number, only a limit; the forecaster's own chance of this, stated with the estimate: 60%; the middle value lies beyond the limit too.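

Within the data shown here, compound 2 and compound 3 both stand only at limits, and no step between them can be read. The compounds shown leave open whether 1H-imidazol-1-yl and pyrrolidin-1-yl differ at all in antiproliferative effect.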